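This account rests on a few compounds, and the source may have more. Where it says the series, first, only, none or still open, it means among the compounds named here.

Measured so far:

- compound 1 `Cc1ccccc1-c1noc([C@@H]2CCCN2C(=O)Nc2ccc(Cl)cc2)n1`; in an ADME assay on MCF-10A cells (Homo sapiens) for inhibition, with a stated time of 48 h (a lower number here means a stronger inhibitor, a higher number a weaker inhibitor), compound 1 gives > 50000 nM, which is a limit of the assay and not a number.
- compound 2 `Cc1cccc(-c2noc([C@@H]3CCCN3C(=O)Nc3ccc(Cl)cc3)n2)c1`; in this assay compound 2 gives > 50000 nM, also a limit.
- compound 3 `O=C(Nc1ccc(Cl)cc1)N1CCC[C@H]1c1nc(-c2ccc(Cl)cc2)no1`; in this assay compound 3 gives > 50000 nM, again a limit.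

Compound 1 therefore stands only at a limit in this assay, as do the two others; (the limit of > 50000 nM in this assay, at which 3 of the 3 values shown sit). The change to compound 4 `O=C(Nc1ccc(Cl)cc1)N1CCC[C@H]1c1nc(-c2ccc(I)cc2)no1` is 4-iodophenyl in place of 2-methylphenyl on an aromatic carbon. Going by the values given here, the steps that bear on it are a step that the two limits leave unreadable from compound 1 to compound 3, a step that the two limits leave unreadable from compound 1 to compound 2 and a step that the two limits leave unreadable from compound 2 to compound 3, none of them readable in size, since every value sits at the limit. The 4-iodophenyl of compound 4 stands closest to the 4-chlorophenyl of compound 3, whose value is a limit. No readable step is expected from compound 1 to compound 4, a number no higher from compound 1 to compound 4 (the limit leaves the size open), and compound 4 is most likely to return a limit as well. The estimate for compound 4 in this assay is 50000 nM, within 20000 nM to 100000 nM.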

Compound 4, half-maximal inhibitory concentration: > 50000 nM
Compound 4: a limit, no number; the forecaster's own chance of this, stated with the estimate: 80%; the middle value lies on the limit itself.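

Compound 4 also gives only a limit in this assay, not a number, so none of its steps from compound 1, compound 2 or compound 3 can be read: the limit of > 50000 nM in this assay, at which 4 of the 4 values shown sit. The compounds shown leave open whether any group in this place on the shared core gives a measurable value in this assay.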